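A few compounds are considered here, and "the series" means these few. Any claim that something is new, unique, unknown or untested is made for them only; others in the source may bear on it.

Measured compounds:
compound 1, `COC(=O)c1c(Nc2ccccc2)sc(C(=O)c2ccc(C)cc2)c1C`, 2.08%
compound 2, `COc1ccc(C(=O)c2sc(Nc3ccccc3)c(C(=O)O)c2C)cc1`, 19.6%

In a functional assay, with a stated time of 150 min, tested at 5 ug/mL (a higher number here means a stronger effect of the compound at the concentration tested, a lower number a weaker effect), compound 2 gives 19.6%, the highest of the two numbers recorded; the nearest is compound 1 with 2.08%, a gap beyond the scatter. For the measured compounds named here, compound 1 and compound 2 differ in more than one place, so no single step between measured compounds is available, and the two values show only that the pair sits well apart. Compound 3, `Cc1ccc(C(=O)c2sc(Nc3ccccc3)c(C(=O)O)c2C)cc1`, is not yet measured in this assay. It differs from compound 2 as follows: methyl in place of methoxy on an aromatic carbon. Going by the values given here, no measured step of this kind exists, so the expectation for compound 3 rests on the two values alone. Compound 3 is expected to fall below compound 2 and toward compound 1, with an expected step of a number 9.6 percentage points lower from compound 2 to compound 3 (within the scatter), a decrease that may or may not exceed the scatter. The estimate for compound 3 is 10%, in the range 0% to 25%.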

Compound 3, a percentage reported as activity, at one concentration (the size of the read-out at that concentration, not a potency): 0.26%
Compound 3: middle estimate off by 9.7 percentage points, on the high side; measured number inside the range.
By their numbers in this assay, from the lowest: compounds 3 and 1 (each within the scatter of the next); then compound 2.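

In this assay, the change from 4-methoxyphenyl to 4-methylphenyl gives a single-place reading at this position: a number 19.3 percentage points lower from compound 2 to compound 3 (beyond the scatter), with the carboxylic acid and the rest of the core kept, so the gap in this pair goes with the methoxy alone. At the other site, going from the methyl ester to the carboxylic acid with 4-methylphenyl kept gives a number 1.8 percentage points lower from compound 1 to compound 3 (within the scatter), so this exchange shows no step beyond the scatter in this pair, whereas the methoxy exchange does. The data hold nothing that explains either result.

On these data alone, it remains open whether the methoxy step carries over when a methyl ester replaces the carboxylic acid. How a hydroxy, an ethoxy or a chlorine at this place would compare with methoxy is also unsettled.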